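The source may hold more compounds than are shown below. What is called first, only, known or untested is meant among the compounds shown, and "the series" means these compounds.

Measured so far:
compound 1 `COc1ccc(C(=O)Nc2cccc(-c3ccnc4c(N)cccc34)c2)cc1OC`: 9500 nM
compound 2 `Nc1cccc2c(-c3cccc(NC(=O)c4nccs4)c3)ccnc12`: 16700 nM

Both were read in a functional assay on A375P cells (Homo sapiens) for antiproliferative activity, read by MTT assay, with a stated time of 48 h; a lower number here means a stronger inhibitor, a higher number a weaker inhibitor. Compound 2 and compound 1 are separated only by a 1.8-fold higher number from compound 1 to compound 2 (0.24 log units; within the scatter), within the scatter, so the two stand level.

Compound 3 `Nc1cccc2c(-c3cccc(NC(=O)c4cc5ccccc5s4)c3)ccnc12` carries 1-benzothiophen-2-yl in place of 1,3-thiazol-2-yl on a carbonyl carbon. For the measured compounds named here, the one step that bears on this is the exchange of the aryl group on the carbonyl carbon from compound 1 to compound 2, which stayed within the scatter; a further exchange at that carbonyl carbon is therefore expected to give no step beyond the scatter. Compound 3 is estimated at 13000 nM (range 4000 nM to 40000 nM), an expected step of a 1.3-fold lower number from compound 2 to compound 3 (0.11 log units; within the scatter).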

Compound 3, half-maximal inhibitory concentration: > 20000 nM
Compound 3 ended at the assay's limit (the forecaster's own chance of this, stated with the estimate: 10%); middle value at least 1.5-fold (0.18 log units) away from the limit.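

Against the 3,4-dimethoxyphenyl group, the exchange on the carbonyl carbon now gives an at least 2.1-fold higher number from compound 1 to compound 3 (0.32 log units; beyond the scatter), the first step at this place to pass the scatter. Against the 1,3-thiazol-2-yl group, the reading is only an at least 1.1-fold higher number from compound 2 to compound 3 (0.07 log units; that floor lies within the scatter), so that pair stays unresolved. Compound 3 stands at a limit of the assay, not at a number: the limit of > 20000 nM in this assay, at which 1 of the 3 values shown sits.

Going by these compounds, the true value of compound 3 stays open. So does the effect on this carbonyl carbon of a simple alkyl chain, or of a phenyl group carrying an amine or a carboxylic acid.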